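Closing the Amine into a Phenylpyrrolidine Ring

The source may report more compounds than this note shows. Statements on the series, on what has been measured and on what is new or still open speak of the compounds shown alone.

Three measured compounds share one core and differ only in the side chain attached to it. Compound 1 `CCCN(CC1CC1)C(=O)c1c(C)nc2n(-c3c(C)cc(C)cc3C)c(Cl)cn12` carries an amide with a propyl and a cyclopropylmethyl group on its nitrogen; in an assay on cells for displacement of a labelled ligand from corticotropin-releasing factor receptor 1 (Homo sapiens), with a stated time of 100 min (on this read-out higher numbers stand for weaker inhibition and lower numbers for stronger inhibition), compound 1 gives 61 nM. Compound 2 `Cc1cc(C)c(-n2c(Cl)cn3c(CN(CCC(F)(F)F)CC4CC4)c(C(F)(F)F)nc23)c(C)c1` carries an amine bearing a cyclopropylmethyl and a 3,3,3-trifluoropropyl group, and in this assay compound 2 gives 16 nM, the lowest of the three numbers and so the strongest inhibition seen here. Compound 3 `Cc1cc(C)c(-n2c(Cl)cn3c(CN(CCC(F)(F)F)Cc4ccccc4)c(C(F)(F)F)nc23)c(C)c1` keeps that amine but has phenyl in place of cyclopropyl; in this assay compound 3 gives 43 nM, and the step of a 2.7-fold higher number from compound 2 to compound 3 (0.43 log units; beyond the scatter) is modest yet beyond the scatter.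

Compound 4 `Cc1cc(C)c(-n2c(Cl)cn3c(CN4CCCC4c4ccccc4)c(C(F)(F)F)nc23)c(C)c1` has not been measured. Relative to compound 2 the change is 2-phenylpyrrolidin-1-yl in place of (cyclopropylmethyl)(3,3,3-trifluoropropyl)amino on a saturated chain carbon bound to an aromatic carbon. Among the measured compounds shown here, only one measured step bears on it: introducing a phenyl in compound 3 weakened inhibition modestly. For the measured compounds named here, no measured step covers closing the amine into a five-membered ring or removing the 3,3,3-trifluoropropyl chain. A modest weakening is therefore expected for compound 4, estimated as a 2.5-fold higher number from compound 2 to compound 4 (0.40 log units; beyond the scatter). In this assay compound 4 is estimated at 40 nM, with a likely range from 12 nM to 130 nM.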

Compound 4, inhibition constant: > 7000 nM
Compound 4 was reported as a limit; the forecaster's own chance of this, stated with the estimate: 5%; middle value at least 170-fold (2.24 log units) away from the limit.
By their numbers in this assay, from the lowest: compound 2; then compounds 3 and 1 (each within the scatter of the next). At a limit, above all of these: compound 4.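

In this assay, among the compounds shown here, the amine on this saturated chain carbon turns out to matter far more than the earlier compounds suggested: replacing the open (cyclopropylmethyl)(3,3,3-trifluoropropyl)amino group with 2-phenylpyrrolidin-1-yl gives an at least 430-fold higher number from compound 2 to compound 4 (2.64 log units; beyond the scatter). The earlier change, phenyl in place of cyclopropyl with the trifluoropropyl chain kept and the amine left open, cost much less, at a 2.7-fold higher number from compound 2 to compound 3 (0.43 log units; beyond the scatter), so bringing in a phenyl does not by itself predict a loss of this size. The leaving and entering groups hold the same number of heavy atoms, and the reading for compound 4 is a limit of the assay and not a number, so the step gives only the smallest possible size of the loss: the limit of > 7000 nM in this assay, at which 1 of the 4 values shown sits.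

Compound 4 closes the amine into a ring, drops the 3,3,3-trifluoropropyl chain and adds a phenyl in a single change, so the compounds shown leave open which of these accounts for the loss. A pyrrolidin-1-yl group without the phenyl, or an open amine keeping the phenyl but with a propyl chain in place of the 3,3,3-trifluoropropyl chain, would begin to separate these parts.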